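The source may hold more compounds than are shown below. What is called first, only, known or untested is meant among the compounds shown, and "the series" means these compounds.

Compound 1 `NC(=O)c1ccc(NCc2nc(-c3ccccc3)nn2-c2ccccc2)cc1` gives -4.4% in an assay on Sf9 cells for inhibition of protein deacetylase HDAC6 (Homo sapiens), read by fluorescence, with a stated time of 40 min, tested at 100 nM (on this read-out lower numbers stand for less inhibition and higher numbers for more inhibition at the one concentration tested (going by the name of the read-out)), the lowest of the two numbers in hand. Compound 2 `O=C(NO)c1ccc(NCc2nc(-c3cccs3)nn2-c2ccc(O)cc2)cc1` gives 79.6% in this assay, a gap to compound 1 that lies beyond the scatter. Compound 3 `CNC(=O)c1ccc(NCc2nc(-c3ccccc3)nn2-c2ccccc2)cc1` is the next entry; it differs from compound 1 by methyl in place of hydrogen on an amide-type nitrogen. Among the measured compounds shown here, no measured pair in the set carries this change, so its effect is not known from data. A small change of this kind is expected to leave the read-out roughly where compound 1 sits, with the expected step of a number 4.4 percentage points higher from compound 1 to compound 3 (within the scatter) staying within the scatter. Compound 3 is thus estimated at 0% in this assay, with a range of -15% to 15%.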

Compound 3, a percentage reported as inhibition, at one concentration (the size of the read-out at that concentration, not a potency): -3.6%
For compound 3 the middle estimate is 3.6 percentage points above the measured one, within the range that was stated.
By their numbers in this assay, from the lowest: compounds 1 and 3 (each within the scatter of the next); then compound 2.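

On the amide-type nitrogen, methyl in place of hydrogen gives in this assay a step of a number 0.8 percentage points higher from compound 1 to compound 3 (within the scatter) and so does not separate the methylcarbamoyl of compound 3 from the carbamoyl of compound 1. Neither amide shows inhibition at the one concentration tested, and adding this methyl does not alter that picture. Nothing in hand bears on why this step is so small.

From the compounds shown here alone, whether ethyl or a longer chain on this nitrogen would behave like methyl stays open. So does the effect of a carboxylic acid in place of the carbamoyl.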